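Fluoro in place of chloro: no clear step expected

This account rests on a few compounds, and the source may have more. Where it says the series, first, only, none or still open, it means among the compounds named here.

Compound 1 `O=C(CCCCC(S)CCS)Nc1ccccc1`: 13.7%
Compound 2 `O=C(CCCCC(S)CCS)Nc1ccc(Cl)cc1`: 21.3%

In a functional assay on HO8910 cells (Homo sapiens) for inhibition, read by MTT assay, with a stated time of 24 h, tested at 100 ug/mL (a higher number here means more inhibition of growth at the concentration tested, a lower number less inhibition of growth), compound 2 gives 21.3%. For the measured compounds named here, with only two measured compounds, its standing rests on a single comparison: a number 7.6 percentage points higher from compound 1 to compound 2 (within the scatter). That change is chloro in place of hydrogen on an aromatic carbon.

Compound 3 `O=C(CCCCC(S)CCS)Nc1ccc(F)cc1` has not yet been measured. Its difference from compound 2 is fluoro in place of chloro on an aromatic carbon. In words, this is fluoro in place of chloro on an aromatic carbon, para to a large group.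

Going by the values given here, no measured step exchanges fluoro for chloro. Among the compounds with values here, the only measured step that bears on the change is therefore a number 7.6 percentage points higher from compound 1 to compound 2 (within the scatter), which involves the same aromatic carbon. With that one step as a guide, no change beyond the scatter is expected in this assay, and no direction is firmly expected. The expected step is a number 2.3 percentage points lower from compound 2 to compound 3 (within the scatter). For compound 3 the estimated value is 19%, with an expected range of 8% to 30%.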

Compound 3, percent growth inhibition at one concentration: 22.3%
For compound 3 the middle estimate is 3.3 percentage points below the measured one; the range from low to high includes it.
By their numbers in this assay, from the lowest: compounds 1, 2 and 3 (each within the scatter of the next).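

At this aromatic carbon, para to a large group, the two halogens can now be compared directly: in this assay, fluoro in place of chloro gives a number 1 percentage points higher from compound 2 to compound 3 (within the scatter), so this exchange does not separate the two compounds. Fluoro in place of hydrogen at the same carbon gives a number 8.6 percentage points higher from compound 1 to compound 3 (within the scatter), which shows that, like chloro, fluoro does not take the reading beyond the scatter from that of compound 1, and the three compounds therefore cannot be ranked. No available evidence bears on this result.

Going by these compounds, it remains open whether a different group at this carbon, such as an amine, a carboxylic acid or a methoxy group, would produce a step beyond the scatter in this assay. Also unresolved are whether a longer chain in the shared core would change the reading and whether the three compounds would separate at a concentration other than the single one tested here.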